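The source may hold more compounds than are shown below. What is called first, only, known or untested is meant among the compounds shown, and "the series" means these compounds.

Of the compounds shown here, three built on the same kind of frame have been tested so far. In a functional assay on HepG2 cells (Homo sapiens) for cytotoxicity, read by MTT assay, with a stated time of 72 h (a lower number here means a stronger inhibitor, a higher number a weaker inhibitor), compound 1 `CNC(=O)c1cc(Oc2ccc(C(=O)/C=C/c3cc(OC)c(OC)c(OC)c3)cc2)ccn1` gives 560 nM. For compound 2 `CNC(=O)c1cc(Oc2ccc(C(=O)/C=C/c3ccc(OC)cc3)cc2)ccn1` the entry reads "not determined" (no result reported), so it offers no number to compare. Compound 3 `CNC(=O)c1cc(Oc2ccc(/C=C/C(=O)c3ccc(Br)cc3)cc2)ccn1` gives 22000 nM, the higher of the two available numbers, and its gap to compound 1 lies beyond the scatter of repeated measurements. Those two compounds differ in more than one place, so that gap cannot show what a single small swap does.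

Compound 4 `CNC(=O)c1cc(Oc2ccc(/C=C/C(=O)c3ccc(Cl)cc3)cc2)ccn1` departs from compound 3 at a single place: chloro in place of bromo on an aromatic carbon, para to a large group. Among the measured compounds shown here, no measured pair shows this swap, so the expectation rests only on compound 3 at 22000 nM and on the small size of the change. The step of a 1.1-fold lower number from compound 3 to compound 4 (0.04 log units; within the scatter) is expected to stay within the scatter, with neither direction favoured. In this assay compound 4 is estimated at 20000 nM, with an expected range from 8000 nM to 50000 nM.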

Compound 4, half-maximal inhibitory concentration: 36600 nM
The estimate for compound 4 lay 1.8-fold (0.26 log units) below the measured number, and the stated range covers the measured number.
By their numbers in this assay, from the lowest: compound 1; then compounds 3 and 4 (each within the scatter of the next).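

In this assay, chloro in place of bromo on an aromatic carbon, para to a large group, gives a 1.7-fold higher number from compound 3 to compound 4 (0.22 log units; within the scatter). Among the compounds shown here, this is the only measured pair here that differs in one place, and it shows that this exchange of one halogen for another, 4-bromophenyl to 4-chlorophenyl, leaves compound 3 and compound 4 indistinguishable in this test. No measurement of any property of these two groups is available, so the result comes without an explanation.

The compounds shown leave open what happens when a very different group, such as an amine, a carboxylic acid or a nitrile, stands on this carbon. A single pair also cannot tell whether the same exchange would behave alike on a different core.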